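From Methoxy to Bromo on the Phenoxy Ring

The source may hold more compounds than are shown below. What is called first, only, known or untested is meant among the compounds shown, and "the series" means these compounds.

Compound 3 `COc1ccc(OCC(=O)N2CCN(c3nc(N)nc4sccc34)CC2)cc1` gives 72 nM in a functional assay on cells (Lymphocyte) (a lower number here means a stronger inhibitor, a higher number a weaker inhibitor), the lowest of the two numbers measured, while compound 2 `Nc1nc(N2CCN(C(=O)COc3ccccc3)CC2)c2ccsc2n1` gives 780 nM. Compound 1 `CCOC(=O)c1nc(N2CCN(C(=O)COc3ccc(Cl)cc3)CC2)c2cc(F)sc2n1` reaches only the limit of this assay, > 10000 nM. Among the measured compounds shown here, the one measured step, from hydrogen to methoxy on the aromatic carbon, is an 11-fold lower number from compound 2 to compound 3 (1.03 log units; beyond the scatter). Compound 4 `Nc1nc(N2CCN(C(=O)COc3ccc(Br)cc3)CC2)c2ccsc2n1` differs from compound 3 by bromo in place of methoxy on an aromatic carbon. For the measured compounds named here, no measured pair exchanges methoxy for bromo, so the only step that bears on this change is the large one into compound 3, which shows that a group at the same place moves the number strongly. Going by the values given here, a bromo there is expected to keep part of that gain, but with no direct precedent the outcome is uncertain, and a moderate loss against compound 3 is the more cautious expectation. The estimate for compound 4 is therefore 150 nM, between 40 nM and 600 nM, which means an expected step of a 2.1-fold higher number from compound 3 to compound 4 (0.32 log units; beyond the scatter) in this assay.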

Compound 4, half-maximal inhibitory concentration: 320 nM
Compound 4: the middle estimate sits 2.1-fold (0.33 log units) below what was measured; the range from low to high includes it.
By their numbers in this assay, from the lowest: compound 3; then compound 4; then compound 2. At a limit, above all of these: compound 1.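

In this assay the gain at this place on the phenoxy ring turns out not to belong to methoxy alone: bromo also does better than hydrogen, with a 2.4-fold lower number from compound 2 to compound 4 (0.39 log units; beyond the scatter) in the stronger direction. Bromo does not match methoxy, however, with a 4.4-fold higher number from compound 3 to compound 4 (0.65 log units; beyond the scatter) as the cost of the exchange, so the number depends on which group stands here and not merely on the place being filled. Nothing among the data at hand explains why these two groups differ.

Still open, from the compounds shown here alone, is whether an amine, a carboxylic acid or a longer chain such as ethoxy at this place would give a lower number than compound 3 does. Also open, going by these compounds, is whether the order of methoxy, bromo and hydrogen seen on the shared core of compound 2, compound 3 and compound 4 would hold on another core.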